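The source may report more compounds than this note shows. Statements on the series, on what has been measured and on what is new or still open speak of the compounds shown alone.

Among the compounds with values here, in an assay on CHO cells for displacement of a labelled ligand from prostaglandin E2 receptor EP1 subtype (Homo sapiens) (a lower number here means a stronger inhibitor, a higher number a weaker inhibitor), compound 2 `CCc1ccccc1N(CC(=O)NCc1cccc(OC)c1)S(=O)(=O)c1ccc(C)cc1` gives 79.4 nM, the highest of the two numbers measured so far; its nearest neighbour, compound 1 `CCc1ccccc1N(CC(=O)NCc1ccc(OC)c(OC)c1)S(=O)(=O)c1ccc(C)cc1`, gives 25.1 nM, and a 3.2-fold higher number from compound 1 to compound 2 (0.50 log units; beyond the scatter) is the only step on record. Compound 3 `CCc1ccccc1N(CC(=O)NCc1cccc(Cl)c1)S(=O)(=O)c1ccc(C)cc1` differs from compound 2 by chloro in place of methoxy on an aromatic carbon. Within the data shown here, no measured step exchanges methoxy for chloro, so only the removal of a methoxy guides the expectation; the exchange is expected to leave compound 2 roughly where it is, leaning weaker, as a 1.3-fold higher number from compound 2 to compound 3 (0.10 log units; within the scatter) in this assay. Compound 3 is therefore estimated at 100 nM, within a range from 30 nM to 320 nM.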

Compound 3, inhibition constant: 251 nM
Beside the measured number, compound 3's estimate is 2.5-fold (0.40 log units) below it; the range from low to high includes it.
By their numbers in this assay, from the lowest: compound 1; then compound 2; then compound 3.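

Exchanging methoxy for chloro on this aromatic carbon gives a 3.2-fold higher number from compound 2 to compound 3 (0.50 log units; beyond the scatter) in this assay, so the methoxy that remains in compound 2 is not interchangeable with chloro here, which the earlier step at the other methoxy could not show. Across both places, the 3,4-dimethoxyphenyl to 3-chlorophenyl change gives a 10-fold higher number from compound 1 to compound 3 (1.00 log units; beyond the scatter). No measurement at hand explains why this exchange moves the number. From the compounds shown here alone, whether hydroxyl, fluoro or methyl on this carbon would stay closer to compound 2 remains open.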